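Longer Chain on the Hydroxy-Bearing Core

This account rests on a few compounds, and the source may have more. Where it says the series, first, only, none or still open, it means among the compounds named here.

Measured so far in a functional assay on A549 cells (Homo sapiens) for inhibition, read by CCK-8 assay, with a stated time of 72 h, tested at 1 uM; a lower number here means a weaker effect, a higher number a stronger effect of the compound at the concentration tested:
compound 1 `CN(C)C(=O)c1cc2cnc(Nc3ccc(C(=O)NCCCCCN=C=S)cc3F)nc2n1C1CCCC1`, compound 1 gives -1.6%
compound 2 `CN(C)C(=O)c1cc2cnc(Nc3ccc(C(=O)NCCCCCCN=C=S)cc3F)nc2n1C1CCCC1`, compound 2 gives -11.8%
compound 3 `CN(C)C(=O)c1cc2cnc(Nc3ccc(C(=O)NCCCN=C=S)cc3O)nc2n1C1CCCC1`, compound 3 gives 55.9%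

Compound 2 differs from compound 1 by a group of 4 heavy atoms (2 carbon, 1 nitrogen, 1 sulfur; no ring) in place of a group of 3 heavy atoms (1 carbon, 1 nitrogen, 1 sulfur; no ring), on a saturated chain carbon, five bonds along the chain from an amide-type nitrogen, and that change made a number 10.2 percentage points lower from compound 1 to compound 2 (beyond the scatter). The difference between the core of compound 1 and the core of compound 3 is not broken down here; compound 3 stands highest of the three, with both other values beyond the scatter from it. Compound 4 `CN(C)C(=O)c1cc2cnc(Nc3ccc(C(=O)NCCCCN=C=S)cc3O)nc2n1C1CCCC1` differs from compound 3 by a group of 4 heavy atoms (2 carbon, 1 nitrogen, 1 sulfur; no ring) in place of a group of 3 heavy atoms (1 carbon, 1 nitrogen, 1 sulfur; no ring), on a saturated chain carbon, three bonds along the chain from an amide-type nitrogen, the same kind of change as before, though here the place is three bonds along the chain from an amide-type nitrogen rather than five. Because the earlier step was a number 10.2 percentage points lower from compound 1 to compound 2 (beyond the scatter), a similar modest lowering is expected, a number 10.9 percentage points lower from compound 3 to compound 4 (beyond the scatter). Compound 4 is therefore estimated at 45%, expected between 20% and 65%.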

Compound 4, a percentage reported as inhibition, at one concentration (the size of the read-out at that concentration, not a potency): 30.3%
Estimate against measurement, compound 4: 14.7 percentage points above, and the stated range covers the measured number.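

Putting the longer chain on the core of compound 3 gives a number 25.6 percentage points lower from compound 3 to compound 4 (beyond the scatter) in this assay. The same change lowers the number on both cores, but its size does not carry over from one core to the other: the same change on two cores in this assay, a number 10.2 percentage points lower (beyond the scatter) from compound 1 to compound 2 and a number 25.6 percentage points lower (beyond the scatter) from compound 3 to compound 4, 15.4 percentage points apart, beyond the scatter of two such steps. These two pairs show a shared direction only; they do not explain the gap in size, and they give no rule for any other core.

The compounds shown leave open how a still longer chain would behave on the core of compound 3, and whether the lowering would continue. They also leave open what an amine would give in place of the sulfur-bearing group on the same chain.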